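Chain-extended hydroxamic acids on two related cores

The source may report more compounds than this note shows. Statements on the series, on what has been measured and on what is new or still open speak of the compounds shown alone.

Compound 1 `Nc1ncnc2c1c(-c1cnc3[nH]ccc3c1)nn2CC(=O)NO` and compound 2 `Nc1ncnc2c1c(-c1cnc3[nH]ccc3c1)nn2CCCCC(=O)NO` share one core, while compound 3 `Nc1nc2cc(-c3nn(CCCCCC(=O)NO)c4ncnc(N)c34)ccc2o1` and compound 4 `Nc1nc2cc(-c3nn(CCCCCCCCC(=O)NO)c4ncnc(N)c34)ccc2o1` share another; the difference between the two cores is not broken down here. In a functional assay on HepG2 cells (Homo sapiens) for inhibition, read by MTT assay, with a stated time of 72 h (a higher number here means a weaker inhibitor, a lower number a stronger inhibitor), compound 1 gives only a limit, > 150000 nM, which is the limit of > 150000 nM in this assay, at which 1 of the 3 values shown sits. In this assay compound 2 gives 36700 nM, so the change 3-(hydroxycarbamoyl)propyl in place of hydroxycarbamoyl on a saturated chain carbon bound to an aromatic nitrogen makes an at least 4.0-fold lower number from compound 1 to compound 2 (0.61 log units; beyond the scatter). Compound 3 gives 1990 nM in this assay, the lowest number among the measured compounds.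

From compound 3 to compound 4 the change is 3-(hydroxycarbamoyl)propyl in place of hydroxycarbamoyl on a saturated chain carbon, five bonds along the chain from an aromatic nitrogen. Among the compounds with values here, it is the same kind of change as the one from compound 1 to compound 2, though there the place was on a saturated chain carbon bound to an aromatic nitrogen, whereas here it is five bonds along the chain from an aromatic nitrogen. Because the earlier change gave an at least 4.0-fold lower number from compound 1 to compound 2 (0.61 log units; beyond the scatter), a lowering of similar kind is expected, and the step is estimated as a 2.8-fold lower number from compound 3 to compound 4 (0.45 log units; beyond the scatter). Compound 4 is therefore expected to give about 700 nM in this assay, estimated between 250 nM and 2500 nM.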

Compound 4, half-maximal inhibitory concentration: 2610 nM
For compound 4 the middle estimate is 3.7-fold (0.57 log units) below the measured one; the measured number lies above the stated range.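

In this assay the new step is a 1.3-fold higher number from compound 3 to compound 4 (0.12 log units; within the scatter), so on the core of compound 3 this lengthening of the chain brings no change that can be told from the scatter. The same change therefore does not carry over unaltered from one core to the other, and the two steps differ: the same change on two cores in this assay, an at least 4.0-fold lower number (0.61 log units; beyond the scatter) from compound 1 to compound 2 and a 1.3-fold higher number (0.12 log units; within the scatter) from compound 3 to compound 4, at least 5.3-fold (0.72 log units) apart, beyond the scatter of two such steps. This does not show that the core alone sets the outcome, for the change also sits at a different place on the chain in each pair, and one end of the earlier step is a limit, not a number: the limit of > 150000 nM in this assay, at which 1 of the 4 values shown sits.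

The compounds shown leave open what a 5-(hydroxycarbamoyl)pentyl chain would give on the core of compound 1, which would set the two cores side by side at one chain, and how a 6-(hydroxycarbamoyl)hexyl chain would read on the core of compound 3. Also open, from the compounds shown here alone, is whether a carboxylic acid in place of the hydroxamic acid end would give a similar reading on either core.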